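Notes on replacing the side group of compound 2

This account rests on a few compounds, and the source may have more. Where it says the series, first, only, none or still open, it means among the compounds named here.

Measured in a functional assay on MCF7 cells (Homo sapiens) for inhibition, read by MTT assay, with a stated time of 48 h; a higher number here means a weaker inhibitor, a lower number a stronger inhibitor:
- compound 1 `CCOC(=O)C1=C(N/C=N/c2cccnc2Cl)Nc2[nH]nc(C)c2C1c1ccc(N(C)C)cc1`: 4180 nM
- compound 2 `CCOC(=O)C1=C(NN=C(C#N)C#N)Nc2[nH]nc(C)c2C1c1ccc(N(C)C)cc1`: 12100 nM

Among the measured compounds shown here, compound 2 holds the higher of the two numbers, with compound 1 its only neighbour. Compound 3 `CCOC(=O)C1=C(N/N=C(/Br)c2ccccc2)Nc2[nH]nc(C)c2C1c1ccc(N(C)C)cc1` differs from compound 2 by a group of 9 heavy atoms (7 carbon, 1 nitrogen, 1 bromine; one six-membered aromatic ring of carbon only) in place of a group of 6 heavy atoms (3 carbon, 3 nitrogen; no ring), on an amine nitrogen. For the measured compounds named here, only one measured step bears on this: a 2.9-fold higher number from compound 1 to compound 2 (0.46 log units; beyond the scatter). That step installed the same group of 6 heavy atoms in place of a group with an aromatic ring and a halogen, so the present change roughly reverses it. One step is thin evidence. The expected step in this assay is a 2.2-fold lower number from compound 2 to compound 3 (0.34 log units; beyond the scatter), opposite in direction to the measured one and of similar size. Compound 3 is estimated at 5500 nM, with an expected range of 2000 nM to 13000 nM.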

Compound 3, half-maximal inhibitory concentration: 78400 nM
For compound 3 the middle estimate is 14-fold (1.15 log units) below the measured one; measured number outside the range, above it.
By their numbers in this assay, from the lowest: compound 1; then compound 2; then compound 3.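

In this assay an aromatic ring and a halogen on the amine nitrogen do not by themselves give a lower number, since the group with the carbon-only ring and bromine gives a 6.5-fold higher number from compound 2 to compound 3 (0.81 log units; beyond the scatter) in this change. Between two groups of 9 heavy atoms, each with a six-membered aromatic ring and a halogen, the step is a 19-fold higher number from compound 1 to compound 3 (1.27 log units; beyond the scatter), so heavy-atom count and ring size alone do not set the number here. No measurement at hand accounts for either step. As far as these compounds go, what a carboxylic acid or a simple amine on this amine nitrogen would give remains open, as does chlorine in place of the bromine.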